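The compounds below may be only part of what the source reports. "The series", "measured", "known", "first", "only" and "open" are said of these compounds alone.

Going by the values given here, compound 1 `c1ccc2c(-c3nnc(-c4ccncc4)o3)c[nH]c2c1` in a functional assay on MIA PaCa-2 cells (Homo sapiens) for cytotoxicity, read by MTT assay (a higher number here means a weaker inhibitor, a lower number a stronger inhibitor), gives 1600 nM, the only actual number among the two results obtained so far. Compound 2 `COc1ccc(-c2nnc(-c3c[nH]c4ccccc34)o2)cc1` in this assay reaches only the assay limit, > 1000000 nM. Note (the limit of > 1000000 nM in this assay, at which 1 of the 2 values shown sits); compound 1 therefore stands alone as a measured figure, with nothing to rank it against. Compound 3 `FC(F)(F)c1nnc(-c2c[nH]c3ccccc23)o1` differs from compound 1 by trifluoromethyl in place of pyridin-4-yl on an aromatic carbon. Among the compounds with values here, no measured step covers such a change. A weakening in this assay is expected, estimated as a 6.3-fold higher number from compound 1 to compound 3 (0.80 log units; beyond the scatter). Compound 3 is accordingly expected near 10000 nM, within 2000 nM to 100000 nM.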

Compound 3, half-maximal inhibitory concentration: > 1000000 nM
Compound 3 gave a limit, no number (the forecaster's own chance of this, stated with the estimate: 30%); middle value at least 100-fold (2.00 log units) away from the limit.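

At this aromatic carbon of the five-membered aromatic ring, trifluoromethyl in place of pyridin-4-yl gives an at least 620-fold higher number from compound 1 to compound 3 (2.79 log units; beyond the scatter), the first step read at this position and one well beyond the scatter. Pyridin-4-yl is thus the only group here whose compound gives a measured number. The value of compound 3 is a limit and not a number: the limit of > 1000000 nM in this assay, at which 2 of the 3 values shown sit.

Open, from the compounds shown here alone, is whether the ring nitrogen of pyridin-4-yl is what matters, which an unsubstituted phenyl or a pyridin-3-yl at this carbon would test. Going by these compounds, how an amine or a short alkyl chain here would read also remains open.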